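Swapping a Pyridine Arm for a Pyrazole Acid

A few compounds are considered here, and "the series" means these few. Any claim that something is new, unique, unknown or untested is made for them only; others in the source may bear on it.

Within the data shown here, compound 1 `COc1ncc(-c2ccc3ncnc(Nc4ccc(OCCCO)nc4)c3c2)cc1NS(=O)(=O)c1ccc(F)cc1F` has the second highest of the three numbers measured so far in a functional assay on A549 cells (Homo sapiens) for antiproliferative activity, read by sulforhodamine B assay, with a stated time of 72 h (a lower number here means a stronger inhibitor, a higher number a weaker inhibitor), where compound 1 gives 9360 nM. Compound 3 `CCCCS(=O)(=O)Nc1cc(-c2ccc3ncnc(Nc4ccc(OCCO)nc4)c3c2)cnc1OC` gives 13300 nM in this assay, a number within the scatter of that of compound 1, so the two cannot be separated. Compound 2 `COc1ncc(-c2ccc3ncnc(Nc4cnn(CCC(=O)O)c4)c3c2)cc1NS(C)(=O)=O` gives 3840 nM, a lower number that lies beyond the scatter. Compound 4 `COc1ncc(-c2ccc3ncnc(Nc4cnn(CC(=O)O)c4)c3c2)cc1NS(=O)(=O)c1ccc(F)cc1F` differs from compound 1 in one place: 1-(carboxymethyl)-1H-pyrazol-4-yl in place of 6-(3-hydroxypropoxy)pyridin-3-yl on a nitrogen on an aromatic ring. Among the measured compounds shown here, no measured pair covers this exact change. Compound 2 also carries a pyrazole bearing a carboxylic acid chain in that place, and its 3840 nM is the only pointer to what such a group does here, though compound 2 differs elsewhere as well. A modest step to a lower number, just beyond the scatter, is therefore expected: a 1.9-fold lower number from compound 1 to compound 4 (0.27 log units; within the scatter). Compound 4 is expected to give 5000 nM, with a range from 1500 nM to 16000 nM.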

Compound 4, half-maximal inhibitory concentration: 5200 nM
The estimate for compound 4 lay 1.0-fold (0.02 log units) below the measured number; low and high end bracket the measured number.
By their numbers in this assay, from the lowest: compounds 2, 4, 1 and 3 (each within the scatter of the next, the first and the last beyond it).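

Among these compounds, with the rest of compound 1 kept, placing 1-(carboxymethyl)-1H-pyrazol-4-yl on the nitrogen in place of 6-(3-hydroxypropoxy)pyridin-3-yl gives a 1.8-fold lower number from compound 1 to compound 4 (0.26 log units; within the scatter) in this assay, the first step here that isolates this position. The five-membered ring with its carboxymethyl chain and the six-membered ring with its hydroxypropoxy chain therefore cannot be told apart in this assay, even though the ring and the end of the chain change together. Nothing available explains this outcome.

Among the compounds shown here, the single step leaves open how much the ring and the chain each contribute, since a pyrazole carrying a hydroxyalkyl chain and a pyridine carrying a carboxylic acid chain remain to be compared with this pair. Also open, as far as these compounds go, is how a longer carboxylic acid chain or a terminal amine would read at this position with the rest of compound 4 unchanged.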